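Replacing the Pyridyl Arm in a Histamine H2 Agonist Series

The compounds below may be only part of what the source reports. "The series", "measured", "known", "first", "only" and "open" are said of these compounds alone.

compound 1 `N=C(NCCCc1c[nH]cn1)NCCC(c1ccc(F)cc1)c1ccccn1`: 7.94
compound 2 `N=C(NCCCc1c[nH]cn1)NCCC(c1ccc(Br)cc1)c1ccccn1`: 6.97
compound 3 `N=C(NCCCc1c[nH]cn1)NCCC(c1ccc(Cl)c(Cl)c1)c1ccccn1`: 7.54

In a functional assay on muscle tissue for agonist activity at histamine H2 receptor (Cavia porcellus) (a higher number here means a more potent compound, by a factor of ten per unit of this negative logarithm, a lower number a less potent compound), compound 1 stands highest of the three measured compounds: compound 3 lies a number 0.40 log units lower from compound 1 to compound 3 (beyond the scatter), and compound 2 lies a number 0.97 log units lower from compound 1 to compound 2 (beyond the scatter). Going from compound 2 to compound 3 gives a number 0.57 log units higher from compound 2 to compound 3 (beyond the scatter). Compound 4 `N=C(NCCCc1c[nH]cn1)NCCC(c1ccccc1)c1ccc(F)cc1` differs from compound 1 by phenyl in place of pyridin-2-yl on a saturated chain carbon bound to an aromatic carbon and a saturated chain carbon. Among the measured compounds shown here, none of the measured steps bears on this change; each of them alters only the halogenated phenyl and leaves the pyridin-2-yl untouched, so the data give no direct guide. The author therefore expects a modest loss for compound 4, a number 0.74 log units lower from compound 1 to compound 4 (beyond the scatter). Compound 4 is estimated at 7.2, within a range from 6.5 to 7.9.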

Compound 4, negative logarithm of the half-maximal effective concentration: 7.45
Compound 4: the middle estimate sits 0.25 log units below what was measured, within the range that was stated.
By their numbers in this assay, from the lowest: compound 2; then compounds 4 and 3 (each within the scatter of the next); then compound 1.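

Among the compounds shown here, compound 4 gives the first reading at the place held by pyridin-2-yl, as the earlier steps changed only the halogenated phenyl. In this assay the exchange for phenyl gives a number 0.49 log units lower from compound 1 to compound 4 (beyond the scatter) and removes the ring nitrogen, so this position responds to the change, while an all-carbon ring still supports agonist activity. No available evidence accounts for this loss.

From the compounds shown here alone, whether a thiazol-2-yl or a cyclohexyl group would fare better here remains open. So does whether the step would be similar with 4-bromophenyl or 3,4-dichlorophenyl in place of 4-fluorophenyl.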